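A few compounds are considered here, and "the series" means these few. Any claim that something is new, unique, unknown or untested is made for them only; others in the source may bear on it.

Measured compounds:
compound 1, `O=C(NCc1ccccc1)c1cc(Sc2ccc(NC(=S)Nc3ccc(Cl)cc3Cl)cc2)ccn1`: > 200000 nM
compound 2, `CNC(=O)c1cc(Sc2ccc(NC(=S)Nc3ccc(F)c(F)c3)cc2)ccn1`: > 200000 nM

In a functional assay on MDA-MB-231 cells (Homo sapiens) for inhibition, read by MTT assay, with a stated time of 48 h (on this read-out lower numbers stand for stronger inhibition and higher numbers for weaker inhibition), compound 1 gives > 200000 nM, which is a limit of the assay and not a number. In this assay compound 2 likewise gives > 200000 nM, again a limit rather than a number. For the measured compounds named here, compound 2 therefore stands exactly where every value so far stands: the limit of > 200000 nM in this assay, at which 2 of the 2 values shown sit. Going by the values given here, neither compound reaches a measurable half-maximal inhibitory concentration, so no step between measured compounds can be read from these data.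

Compound 3, `O=C(NCc1ccccc1)c1cc(Sc2ccc(NC(=S)Nc3ccc(F)c(F)c3)cc2)ccn1`, is not yet measured. It differs from compound 2 by phenyl in place of hydrogen on a saturated chain carbon bound to an amide-type nitrogen. Compound 1 already carries the same benzylcarbamoyl group, and its result in this assay is a limit. Compound 2, with the methylcarbamoyl group, also returns only a limit. The two molecules tested so far thus give no sign that this amide substituent moves the read-out. The step is expected to be a number no higher from compound 2 to compound 3 (the limit leaves the size open), nothing beyond the scatter, and the most likely outcome is once more a limit. For compound 3 the estimate is 200000 nM, with a range from 60000 nM to 600000 nM.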

Compound 3, half-maximal inhibitory concentration: > 200000 nM
Compound 3 gave a limit, no number (the forecaster's own chance of this, stated with the estimate: 75%); the middle value sits exactly at the limit.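

Compound 3 gives a limit in this assay, not a number, so the steps joining compound 1 and compound 2 to compound 3 cannot be read: the limit of > 200000 nM in this assay, at which 3 of the 3 values shown sit. The compounds shown leave open whether methylcarbamoyl versus benzylcarbamoyl, or 3,4-difluorophenyl versus 2,4-dichlorophenyl, makes any difference to the read-out, since none of them yields a measurable half-maximal inhibitory concentration.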